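The source may hold more compounds than are shown below. What is called first, only, known or untested is meant among the compounds shown, and "the series" means these compounds.

In an ADME assay (on this read-out lower numbers stand for a shorter-lived compound and higher numbers for a longer-lived compound), compound 2 `COCOc1cc(OC)ccc1C[S+]([O-])c1ncccc1C(=O)Nc1ccncc1` reads < 0.02 h, which is a limit of the assay and not a number. Compound 1 `COc1ccc(C[S+]([O-])c2ncccc2C(=O)Nc2ccncc2)c(OC)c1` reads < 0.02 h, again a limit. Compound 2 therefore has no numerical position in the series, only a place at the assay limit.

Compound 3 `COc1ccc(C[S+]([O-])c2ncccc2C(=O)Nc2ccncc2)cc1` carries hydrogen in place of methoxymethoxy on an aromatic carbon, ortho to a large group and meta to a methoxy group: hydrogen in place of methoxymethoxy on an aromatic carbon.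

Within the data shown here, only one measured step bears on this change, a step that the two limits leave unreadable from compound 1 to compound 2. It involves the same side of the molecule, but it gives neither a size nor a direction to carry over. The data therefore offer no measured basis for a shift in this assay, and compound 3 is expected to stay in the same region because of the limit of < 0.02 h in this assay, at which 2 of the 2 values shown sit. No step beyond the scatter is expected, and the estimated step is a step that the limit leaves unreadable from compound 2 to compound 3. A reading reported only as a limit is the most likely outcome.

For compound 3 the estimated half-life is 0.015 h, with an expected range of 0.006 h to 0.04 h.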

Compound 3, half-life: 2.14 h
Beside the measured number, compound 3's estimate is 140-fold (2.15 log units) below it, and the stated range ends below it.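

In this assay, the aromatic carbon ortho to a large group and meta to a methoxy group proves decisive for the read-out: hydrogen in place of methoxymethoxy gives an at least 100-fold higher number from compound 2 to compound 3 (2.02 log units; beyond the scatter), and hydrogen in place of methoxy on the same carbon gives an at least 100-fold higher number from compound 1 to compound 3 (2.02 log units; beyond the scatter). The unreadable step between the two earlier compounds could not show this, since both methoxy and methoxymethoxy on this carbon go with a reading at the limit, while hydrogen there gives a measurable half-life, and the methoxy group kept in compound 3 evidently does not by itself hold the reading at the limit. Both new steps fix only a minimum size, and methoxy and methoxymethoxy cannot be ranked against each other on this carbon: the limit of < 0.02 h in this assay, at which 2 of the 3 values shown sit.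

Still open, from the compounds shown here alone, is whether any group on this carbon pulls the half-life back to the limit or only groups joined through oxygen do, a question that a methyl group, a fluorine atom or a hydroxyl group there would help to settle. Also open, going by these compounds, is how the half-life responds to changes at the methoxy group that compound 3 keeps, for instance hydrogen or a longer chain such as ethoxy in its place.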